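The compounds below may be only part of what the source reports. "The series", "measured", "known", "first", "only" and "open" are said of these compounds alone.

Compound 2 `CCc1c(C(=O)OC)[n+]([O-])c2cc(Cl)c(Cl)cc2[n+]1[O-]` gives 4 ug/mL in an ADME assay on Vero cells (Chlorocebus sabaeus) for cytotoxicity (on this read-out lower numbers stand for stronger inhibition and higher numbers for weaker inhibition), the highest of the two numbers recorded there. Compound 1 `CCc1c(C(=O)OC)[n+]([O-])c2cc(Cl)ccc2[n+]1[O-]` returns only a limit, > 10 ug/mL, as the line the limit of > 10 ug/mL in this assay, at which 1 of the 3 values shown sits, records. Compound 3 `CCOC(=O)COC(=O)c1c(CC)[n+]([O-])c2cc(Cl)c(Cl)cc2[n+]1[O-]` gives 1.22 ug/mL. Among the measured steps there is an at least 2.5-fold lower number from compound 1 to compound 2 (0.39 log units; beyond the scatter) and a 3.3-fold lower number from compound 2 to compound 3 (0.52 log units; beyond the scatter). Compound 4 `C=CCc1c(C(=O)OC)[n+]([O-])c2cc(Cl)c(Cl)cc2[n+]1[O-]` is not yet measured; relative to compound 2 it shows (vinyl in place of methyl on a saturated chain carbon bound to an aromatic carbon). Neither measured step resembles this change, which touches only the alkyl chain on the core, so no shift beyond the scatter is expected from it. Compound 4 is therefore expected to give about 3.5 ug/mL, within 1.5 ug/mL to 8 ug/mL. The expected step of a 1.1-fold lower number from compound 2 to compound 4 (0.06 log units; within the scatter) lies within the usual scatter.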

Compound 4, half-maximal inhibitory concentration: 5.8 ug/mL
The estimate for compound 4 lay 1.7-fold (0.22 log units) below the measured number; the measured number falls inside the stated range.
By their numbers in this assay, from the lowest: compound 3; then compounds 2 and 4 (each within the scatter of the next). At a limit, above all of these: compound 1.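

In this assay, the first change shown on the alkyl chain, vinyl in place of methyl, gives a 1.5-fold higher number from compound 2 to compound 4 (0.16 log units; within the scatter). Unlike the chloro and ethoxycarbonyl changes, whose steps lay beyond the scatter, this one stays within it, so the added carbon and double bond produce no readable shift at this place. Nothing among the data shown bears on the reason for this.

On these data alone, it remains open whether a longer chain, a phenyl or an amine on this carbon would move the number beyond the scatter. Also open, as far as these compounds go, is whether the allyl group would behave the same way alongside the ethoxycarbonyl group of compound 3.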